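Chloro to Bromo on the Pendant Phenyl Ring

The source may report more compounds than this note shows. Statements on the series, on what has been measured and on what is new or still open speak of the compounds shown alone.

Compound 1 `Cn1ccc2c(Oc3ccc(NC(=O)c4cc5cccnc5n(-c5ccccc5)c4=O)cc3F)ccnc21` gives 3590 nM in a functional assay on U-87MG ATCC cells for antiproliferative activity against U-87 MG (Homo sapiens), read by MTT assay, with a stated time of 72 h; a higher number here means a weaker inhibitor, a lower number a stronger inhibitor. Compound 2 `Cn1ccc2c(Oc3ccc(NC(=O)c4cc5cccnc5n(-c5ccc(Cl)cc5)c4=O)cc3F)ccnc21` carries a 4-chlorophenyl group in place of that phenyl, but in this assay compound 2 gives "not determined" (no result reported), so it stands without a number. Compound 3 `Cn1ccc2c(Oc3ccc(NC(=O)c4cc5cccnc5n(-c5ccc(Br)cc5)c4=O)cc3F)ccnc21` differs from compound 2 by bromo in place of chloro on an aromatic carbon. Within the data shown here, no step between two measured compounds covers this change, and since compound 2 has no value, the expectation for compound 3 rests on compound 1 alone. Compound 3 is estimated at 3000 nM, within a range of 900 nM to 10000 nM, with no shift beyond the scatter expected.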

Compound 3, half-maximal inhibitory concentration: 2580 nM
The estimate for compound 3 lay 1.2-fold (0.07 log units) above the measured number, within the range that was stated.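

In this assay, among these compounds, bromo in place of hydrogen on this aromatic carbon gives a 1.4-fold lower number from compound 1 to compound 3 (0.14 log units; within the scatter) and this supplies the first measured number for a halogen at this position, level with that of the plain phenyl. Compound 2 has no number, and the step from chloro to bromo cannot be read. Nothing measured here bears on this result. On these data alone, whether a methoxy group, an amine or a carboxylic acid at this position would move the number beyond the scatter remains open. So does whether another place on the pendant phenyl ring would respond differently.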